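The source may hold more compounds than are shown below. What is called first, only, known or untested is meant among the compounds shown, and "the series" means these compounds.

Compound 2, `COc1cccc(OC)c1OCCNCCOc1ccccc1OCc1ccc(C)cc1`, is the compound from which the next step sets out. Among the compounds with values here, in a functional assay on PC-3 cells (Homo sapiens) for cytotoxicity, read by sulforhodamine B assay (a lower number here means a stronger inhibitor of growth, a higher number a weaker inhibitor of growth), compound 2 gives 7800 nM, the lowest of the two numbers known so far; its nearest neighbour is compound 1, `COc1cccc(OC)c1OCCNCCOc1ccccc1OCc1cccc(C)c1`, which in this assay gives 12000 nM, and the step of a 1.5-fold lower number from compound 1 to compound 2 (0.19 log units; within the scatter) stays within the scatter. Compound 3, `COc1cccc(OC)c1OCCNCCOc1ccccc1OCc1cccc([N+](=O)[O-])c1`, has not yet been measured in this assay. It differs from compound 2 by 3-nitrophenyl in place of 4-methylphenyl on a saturated chain carbon bound to an oxygen on an aromatic ring. Within the data shown here, only one measured step exists, that from 3-methylphenyl to 4-methylphenyl, and it was within the scatter; no measured step replaces a methyl-bearing ring by a nitro-bearing one, so the data give little guidance on the size or direction of the change. Compound 3 is therefore expected to stay close to compound 2, with a step of a 1.2-fold higher number from compound 2 to compound 3 (0.06 log units; within the scatter), and its estimated value in this assay is 9000 nM, within a range from 3000 nM to 25000 nM.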

Compound 3, concentration for 50% growth inhibition: 13200 nM
For compound 3 the middle estimate is 1.5-fold (0.17 log units) below the measured one; measured number inside the range.
By their numbers in this assay, from the lowest: compounds 2, 1 and 3 (each within the scatter of the next).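

In this assay, 3-nitrophenyl in place of 4-methylphenyl on a saturated chain carbon bound to an oxygen on an aromatic ring gives a 1.7-fold higher number from compound 2 to compound 3 (0.23 log units; within the scatter), so this position accepts a nitro-bearing ring with no difference beyond the scatter. The comparison of nitro in place of methyl on an aromatic carbon, which isolates the group itself, gives a 1.1-fold higher number from compound 1 to compound 3 (0.04 log units; within the scatter), and this too cannot be told apart from repeated measurement. Nothing measured here explains these numbers.

The compounds shown leave open whether any group on this ring can move the number beyond the scatter, for instance an amine or a carboxylic acid in place of the nitro. They also leave open what 4-nitrophenyl or a longer chain in place of the benzyl link would give.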